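Swapping pentafluorophenyl for naphthalen-2-yl: an expectation

A few compounds are considered here, and "the series" means these few. Any claim that something is new, unique, unknown or untested is made for them only; others in the source may bear on it.

Compound 1 `CC(=O)N[C@H]1[C@H]([C@@H](O)[C@H](O)CNC(=O)c2ccc(Cl)cc2)O[C@@](OCc2ccc(F)cc2)(C(=O)O)C[C@@H]1O`: -0.11
Compound 2 `CC(=O)N[C@H]1[C@H]([C@@H](O)[C@H](O)CNC(=O)c2ccc(Cl)cc2)O[C@@](OCc2c(F)c(F)c(F)c(F)c2F)(C(=O)O)C[C@@H]1O`: -0.11

In a physicochemical assay for lipophilicity, using the shake flask method, measured as octanol-water partition, at pH 7.4 (a lower number here means a more polar compound, a higher number a more lipophilic compound), compound 2 stands at -0.11, level with compound 1 at -0.11. The next molecule, compound 3 `CC(=O)N[C@H]1[C@H]([C@@H](O)[C@H](O)CNC(=O)c2ccc(Cl)cc2)O[C@@](OCc2ccc3ccccc3c2)(C(=O)O)C[C@@H]1O`, carries naphthalen-2-yl in place of 2,3,4,5,6-pentafluorophenyl on a saturated chain carbon bound to an oxygen on a saturated carbon. Among the measured compounds shown here, only one measured step bears on this change: no change at the digits printed from compound 1 to compound 2 (within the scatter), where 2,3,4,5,6-pentafluorophenyl replaced 4-fluorophenyl at that same place. That step stayed within the scatter. It is thin ground, however, since neither of its groups is naphthalen-2-yl, so the range here is kept wide. The step expected is a number 0.21 log units higher from compound 2 to compound 3 (within the scatter), small and slightly upward, and it is not expected to pass the scatter. For compound 3 the estimated value in this assay is 0.1, with an expected range from -0.3 to 0.5.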

Compound 3, distribution coefficient: 0.58
Compound 3: the middle estimate sits 0.48 log units below what was measured; measured number above the stated range.
By their numbers in this assay, from the lowest: compounds 1 and 2 (each within the scatter of the next); then compound 3.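

In this assay, the place on a saturated chain carbon bound to an oxygen on a saturated carbon can clearly shift the number: naphthalen-2-yl gives a number 0.69 log units higher from compound 2 to compound 3 (beyond the scatter), and against 4-fluorophenyl it gives a number 0.69 log units higher from compound 1 to compound 3 (beyond the scatter). Compounds 1 and 2, each with one six-membered aromatic ring in this group, sit level, so among these three only the group with two such rings stands apart. Nothing measured here accounts for that difference.

Going by these compounds, it remains open whether the second ring as such goes with the step, or only this particular arrangement of it; naphthalen-1-yl, quinolin-2-yl or plain phenyl at the same place would bear on that. On these data alone, how the number would answer to an amine or a carboxylic acid on the naphthalene ring also remains unknown.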